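Swapping Bromo for Nitro on the Aromatic Ring

The source may hold more compounds than are shown below. What is called first, only, known or untested is meant among the compounds shown, and "the series" means these compounds.

- Compound 1 `C/C(=N\NC(=O)/C(C#N)=C/c1ccccc1)c1c(O)c2ccc(O)cc2oc1=O`: 13500 nM
- Compound 2 `C/C(=N\NC(=O)/C(C#N)=C/c1ccc(Br)cc1)c1c(O)c2ccc(O)cc2oc1=O`: 12100 nM
- Compound 3 `C/C(=N\NC(=O)/C(C#N)=C/c1ccc([N+](=O)[O-])cc1)c1c(O)c2ccc(O)cc2oc1=O`: not yet measured

In a functional assay on SK-N-SH cells (Homo sapiens) for cytotoxicity, read by MTT assay, with a stated time of 24 h (on this read-out lower numbers stand for stronger inhibition and higher numbers for weaker inhibition), compound 2 gives 12100 nM, and compound 1 gives 13500 nM. Among the measured compounds shown here, these two values lie within the scatter of each other, so compound 2 does not stand apart from the only other measured compound.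

Compound 3 differs from compound 2 at one place: nitro in place of bromo on an aromatic carbon.

For the measured compounds named here, only one measured step bears on this change: a 1.1-fold lower number from compound 1 to compound 2 (0.05 log units; within the scatter). It put bromo in place of hydrogen on an aromatic carbon, and it stayed within the scatter. Going by the values given here, no measured compound carries a nitro group, so the data offer no firm direction for the change. A step beyond the scatter in this assay is therefore not expected. The expected step is a 1.1-fold lower number from compound 2 to compound 3 (0.04 log units; within the scatter), which is no real change. For compound 3 the estimated value is 11000 nM, with an expected range from 5000 nM to 24000 nM.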

Compound 3, half-maximal inhibitory concentration: 10300 nM
Compound 3: middle estimate off by 1.1-fold (0.03 log units), on the high side, within the range that was stated.
By their numbers in this assay, from the lowest: compounds 3, 2 and 1 (each within the scatter of the next).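

In this assay, the ring carbon para to a large group has now carried a second substituent, and replacing bromo with nitro gives a 1.2-fold lower number from compound 2 to compound 3 (0.07 log units; within the scatter) and so stays within the scatter. Measured against the unsubstituted parent, nitro in place of hydrogen gives a 1.3-fold lower number from compound 1 to compound 3 (0.12 log units; within the scatter) and also stays within the scatter, so hydrogen, bromo and nitro at this carbon cannot be told apart in this cytotoxicity read-out, whereas compound 2 alone had shown this for bromo only. The three compounds therefore give no ranking of these groups, and a change of atoms as large as 4-bromophenyl to 4-nitrophenyl leaves the reading where it was, though nothing available explains why these readings stay together.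

The three compounds leave open whether this carbon tolerates every kind of group or only the two tried so far, since an amine, a carboxylic acid or a longer chain such as butoxy could still move the value beyond the scatter. They also leave open whether any change elsewhere on the phenyl ring, or on the shared core, would do so.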